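Hydroxy to chloro: working notes on compound 4

This account rests on a few compounds, and the source may have more. Where it says the series, first, only, none or still open, it means among the compounds named here.

compound 1 `COc1ccc(-c2noc(-c3ccccc3)n2)cc1OC1CCCC1`: > 1000000 nM (a limit of the assay)
compound 2 `COc1ccc(-c2noc(-c3ccncc3)n2)cc1OC1CCCC1`: 9330 nM
compound 3 `COc1ccc(-c2noc(-c3ccc(O)cc3)n2)cc1OC1CCCC1`: 480 nM

All three were tested in a functional assay on MIA PaCa-2 cells (Homo sapiens) for antiproliferative activity, read by MTT assay, with a stated time of 24 h; a lower number here means a stronger inhibitor, a higher number a weaker inhibitor. Compound 3 holds the lowest number of the series at 480 nM. The nearest number belongs to compound 2, and the link between them is a 19-fold lower number from compound 2 to compound 3 (1.29 log units; beyond the scatter). Compound 1 stands at the limit of > 1000000 nM in this assay, at which 1 of the 3 values shown sits, which is a limit and not a number.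

The next compound is compound 4 `COc1ccc(-c2noc(-c3ccc(Cl)cc3)n2)cc1OC1CCCC1`, with chloro in place of hydroxy on an aromatic carbon, para to a large group: chloro in place of hydroxy on an aromatic carbon. The step that bears most directly is an at least 2000-fold lower number from compound 1 to compound 3 (3.31 log units; beyond the scatter), since it adds the hydroxy that compound 4 gives up. The other change at this end of the molecule, an at least 100-fold lower number from compound 1 to compound 2 (2.03 log units; beyond the scatter), was also large and beyond the scatter. Within the data shown here, no chloro compound has been measured, so these steps fix the direction better than the size. A large move to a higher number in this assay is expected, though compound 4 need not go as far as the limit reached by compound 1. The estimated change is a 31-fold higher number from compound 3 to compound 4 (1.49 log units; beyond the scatter). For compound 4 the expected value is 15000 nM, with an estimated range of 1500 nM to 300000 nM.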

Compound 4, half-maximal inhibitory concentration: 740 nM
Compound 4: middle estimate off by 20-fold (1.31 log units), on the high side, outside the stated range (below it).
By their numbers in this assay, from the lowest: compounds 3 and 4 (each within the scatter of the next); then compound 2. At a limit, above all of these: compound 1.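

At this place, on an aromatic carbon para to a large group, the hydroxy is not needed for the activity seen in this assay: a 1.5-fold higher number from compound 3 to compound 4 (0.19 log units; within the scatter), so the exchange of 1 hydrogen-bond donor and 1 hydrogen-bond acceptor for chloro, with 0 of each, leaves compound 3 and compound 4 indistinguishable. The large step seen earlier on adding hydroxy is therefore not tied to hydroxy alone: chloro in place of hydrogen also gives an at least 1300-fold lower number from compound 1 to compound 4 (3.13 log units; beyond the scatter), and 4-chlorophenyl, set against pyridin-4-yl, gives a 13-fold lower number from compound 2 to compound 4 (1.10 log units; beyond the scatter). In the first of these two steps, the value of compound 1 is a limit and not a number, so that step has a lower bound on its size only: the limit of > 1000000 nM in this assay, at which 1 of the 4 values shown sits.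

On these data alone, with only hydroxy and chloro at this place, it remains open whether other groups, such as fluoro, an amine or a carboxylic acid, would give numbers in the same range or return towards compound 1. The compounds shown also leave open how much bulk the place accepts, which a longer chain such as butoxy would test.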